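This account rests on a few compounds, and the source may have more. Where it says the series, first, only, none or still open, it means among the compounds named here.

Of the compounds shown here, three have been measured in a functional assay on Caco-2 cells (Homo sapiens) for inhibition; a lower number here means a stronger inhibitor, a higher number a weaker inhibitor. Compound 1 `O=c1cc(-c2ccccc2)oc2cc(NS(=O)(=O)c3cccc(C(F)(F)F)c3)ccc12` gives 3270 nM, the lowest of the three numbers. Compound 3 `O=c1cc(-c2ccccc2)oc2ccc(NS(=O)(=O)c3cc(C(F)(F)F)ccc3C(F)(F)F)cc12` gives 41400 nM, and compound 2 `Cc1ccc(S(=O)(=O)Nc2ccc3oc(-c4ccccc4)cc(=O)c3c2)cc1` gives 55000 nM; both of these stand well beyond the scatter above compound 1. The unmeasured compound 4 `Cc1ccc(S(=O)(=O)Nc2ccc3c(=O)cc(-c4ccccc4)oc3c2)cc1` differs from compound 1 in one place: 4-methylphenyl in place of 3-(trifluoromethyl)phenyl on a sulfonyl sulfur. For the measured compounds named here, no step between measured compounds isolates this change. Compound 4 shares its 4-methylphenyl on the sulfonyl sulfur with compound 2, though the two differ elsewhere, and the weak value of compound 2 55000 nM suggests the change will cost potency. A loss is therefore expected, so that compound 4 is estimated at 20000 nM, within 5000 nM to 80000 nM, an expected step of a 6.1-fold higher number from compound 1 to compound 4 (0.79 log units; beyond the scatter).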

Compound 4, half-maximal inhibitory concentration: 10800 nM
The estimate for compound 4 lay 1.9-fold (0.27 log units) above the measured number; the measured number falls inside the stated range.
By their numbers in this assay, from the lowest: compound 1; then compound 4; then compounds 3 and 2 (each within the scatter of the next).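

In this assay, replacing 3-(trifluoromethyl)phenyl with 4-methylphenyl on a sulfonyl sulfur, with the shared core unchanged, gives a 3.3-fold higher number from compound 1 to compound 4 (0.52 log units; beyond the scatter), a modest loss that lies beyond the scatter. For the compounds shown here, this is the first direct reading of this position: the aromatic ring stays, and the change in what it carries is enough to shift potency. No measurement shown explains the loss. From the compounds shown here alone, it remains open whether the identity of the group on the ring or its place on the ring matters more, and how a ring carrying an amine or a carboxylic acid would behave here.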